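The source may report more compounds than this note shows. Statements on the series, on what has been measured and on what is new or still open speak of the compounds shown alone.

Three compounds have been measured in a functional assay on HeLa cells (Homo sapiens) for cytotoxicity, read by MTT assay, with a stated time of 72 h; a lower number here means a stronger inhibitor, a higher number a weaker inhibitor:

Compound 1 `Cc1ccc(CSc2cc(Cl)c(C)cc2S(=O)(=O)/N=C(\N)n2nc(C)cc2-c2ccccc2)cc1`: 62000 nM
Compound 2 `Cc1cccc(CSc2cc(Cl)c(C)cc2S(=O)(=O)/N=C(\N)n2nc(C)cc2-c2ccccc2)c1`: 155000 nM
Compound 3 `Cc1cc(-c2ccccc2)n(/C(N)=N/S(=O)(=O)c2cc(C)c(Cl)cc2SCc2cccc(Cl)c2)n1`: 8000 nM

Compound 3 stands lowest of the three, seen in a 7.8-fold lower number from compound 1 to compound 3 (0.89 log units; beyond the scatter) and a 19-fold lower number from compound 2 to compound 3 (1.29 log units; beyond the scatter). Compound 4 `Cc1cc(-c2ccccc2)n(/C(N)=N/S(=O)(=O)c2cc(C)c(Cl)cc2SCc2ccccc2C(F)(F)F)n1` differs from compound 3 by 2-(trifluoromethyl)phenyl in place of 3-chlorophenyl on a saturated chain carbon bound to a sulfur. Among the measured compounds shown here, the steps that bear on this all alter the same position: a 2.5-fold higher number from compound 1 to compound 2 (0.40 log units; beyond the scatter) was modest, while the two steps reaching compound 3 were modest to large. None of them involves a trifluoromethyl group, so the direction is uncertain; still, as both other variants at this position gave higher numbers than compound 3, a modest rise is expected, a 2.5-fold higher number from compound 3 to compound 4 (0.40 log units; beyond the scatter). Compound 4 is therefore estimated at 20000 nM, within a range from 5000 nM to 80000 nM.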

Compound 4, half-maximal inhibitory concentration: 215000 nM
Compound 4: middle estimate off by 11-fold (1.03 log units), on the low side; the measured number lies above the stated range.
By their numbers in this assay, from the lowest: compound 3; then compound 1; then compounds 2 and 4 (each within the scatter of the next).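

In this assay, among the compounds shown here, the position on the saturated chain carbon bound to a sulfur proves more sensitive than the earlier compounds showed, with a 27-fold higher number from compound 3 to compound 4 (1.43 log units; beyond the scatter) the largest step so far and a 3.5-fold higher number from compound 1 to compound 4 (0.54 log units; beyond the scatter) adding a modest one. The step of a 1.4-fold higher number from compound 2 to compound 4 (0.14 log units; within the scatter) leaves those two compounds indistinguishable, and compound 3 remains lowest of the four. No measurement here accounts for these differences. A 3-(trifluoromethyl)phenyl or a 2-chlorophenyl group could help separate the effect of the group from that of its location on the ring. Going by these compounds, what an amine on that ring would do also remains open.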